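The source may hold more compounds than are shown below. What is called first, only, known or untested is meant among the compounds shown, and "the series" means these compounds.

Measured in an ADME assay on HepG2 cells (Homo sapiens) for cytotoxicity, read by MTT assay, with a stated time of 72 h; on this read-out higher numbers stand for lower toxicity in this test and lower numbers for higher toxicity in this test:
- Compound 1 `COc1cccc(C#Cc2cc(Cl)cn3c([N+](=O)[O-])c(CS(=O)(=O)c4ccccc4)nc23)c1`: > 3900 nM, a limit
- Compound 2 `O=[N+]([O-])c1c(CS(=O)(=O)c2ccccc2)nc2c(C#Cc3ccc(F)cc3)cc(Cl)cn12`: > 3900 nM, a limit
- Compound 3 `CC(O)(C#Cc1cc(Cl)cn2c([N+](=O)[O-])c(CS(=O)(=O)c3ccccc3)nc12)c1ccccc1`: 18800 nM

Within the data shown here, compound 3 gives the only number at 18800 nM. The other two results are limits, as shown by the limit of > 3900 nM in this assay, at which 2 of the 3 values shown sit.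

Compound 4 `CC(O)C#Cc1cc(Cl)cn2c([N+](=O)[O-])c(CS(=O)(=O)c3ccccc3)nc12` follows from compound 3 by hydrogen in place of phenyl on a saturated chain carbon bound to an oxygen on a saturated carbon, a saturated chain carbon and a triple-bonded carbon. The same difference reads 1-hydroxy-1-phenylethyl to 1-hydroxyethyl.

The nearest measured changes are a step that the limit leaves unreadable from compound 1 to compound 3 and a step that the limit leaves unreadable from compound 2 to compound 3. Neither has a readable size, so neither sets a direction or a magnitude.

In this assay, no change beyond the scatter is expected, and the estimated step is a 1.2-fold higher number from compound 3 to compound 4 (0.07 log units; within the scatter).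

The expected value for compound 4 is 22000 nM, with an estimated range of 8000 nM to 60000 nM.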

Compound 4, half-maximal cytotoxic concentration: 44200 nM
Estimate against measurement, compound 4: 2.0-fold (0.30 log units) below; the range from low to high includes it.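

In this assay, 1-hydroxyethyl in place of 1-hydroxy-1-phenylethyl on the triple-bonded carbon gives a 2.4-fold higher number from compound 3 to compound 4 (0.37 log units; beyond the scatter). Among these compounds, this is the only readable step at this position, and it shows that losing the phenyl moves the series toward lower toxicity in this test. The steps from compound 1 and compound 2 to compound 4 cannot be read because of the limit: the limit of > 3900 nM in this assay, at which 2 of the 4 values shown sit.

Going by these compounds, how 1-hydroxyethyl ranks against 3-methoxyphenyl and 4-fluorophenyl stays open. So does the effect of an amine or a longer chain on the triple-bonded carbon.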